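Phenoxy Replaces the Fluoromethylphenyl End of Compound 3

The compounds below may be only part of what the source reports. "The series", "measured", "known", "first", "only" and "open" are said of these compounds alone.

Measured so far:
compound 1 `Cc1c(CCCC(=O)O)c2cccc(/C=C/c3ccc(OCCCCc4ccccc4)cc3)c2n1CC(=O)O` gives 33%
compound 2 `Cc1c(F)cccc1CCCCOc1ccc(/C=C/c2cccc3c(CCCC(=O)O)c(C)n(CC(=O)O)c23)cc1` gives 94%
compound 3 `Cc1c(F)cccc1CCCCOc1ccc(/C=C/c2cccc3c(CCCC(=O)O)cn(CC(=O)O)c23)cc1` gives 97%

These three numbers come from a functional assay on the whole organism for inhibition, with Cavia porcellus as the target, with stated times of 1 h and 10 min, at a dose of 1 mg/kg by the oral route; a higher number here means a stronger effect of the compound at the dose given, a lower number a weaker effect. Compound 3 stands highest of the three, but its step from compound 2, a number 3 percentage points higher from compound 2 to compound 3 (within the scatter), lies within the scatter, so the two cannot be told apart; compound 1 stands far below both.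

Compound 4 `O=C(O)CCCc1cn(CC(=O)O)c2c(/C=C/c3ccc(OCCCCOc4ccccc4)cc3)cccc12` has not yet been measured in this assay. Its difference from compound 3 is phenoxy in place of 3-fluoro-2-methylphenyl on a saturated chain carbon, four bonds along the chain from an oxygen on an aromatic ring. Among the measured compounds shown here, of the measured steps, only the one from compound 1 to compound 2 bears on this change, since it altered the same chain end: a number 61 percentage points higher from compound 1 to compound 2 (beyond the scatter). Compound 4 moves part of the way back toward the chain end of compound 1, with the oxygen added, while keeping the hydrogen on the aromatic carbon that compound 3 has, a change whose step a number 3 percentage points higher from compound 2 to compound 3 (within the scatter) was small. A step downward beyond the scatter is therefore expected for compound 4, though its size is uncertain, estimated as a number 52 percentage points lower from compound 3 to compound 4 (beyond the scatter). Compound 4 is expected to give about 45%, in a range from 15% to 80%.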

Compound 4, a percentage reported as inhibition, in the whole organism at one dose (the size of the read-out at that dose, not a potency): 97%
The estimate for compound 4 lay 52 percentage points below the measured number; measured number outside the range, above it.
By their numbers in this assay, from the lowest: compound 1; then compounds 2, 3 and 4 (each within the scatter of the next).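

In this assay, the step of no change at the digits printed from compound 3 to compound 4 (within the scatter) shows that this chain end accepts phenoxy in place of 3-fluoro-2-methylphenyl, so the fluorine and methyl of compound 3 are not needed for a full read-out once phenoxy stands there. The large step of a number 61 percentage points higher from compound 1 to compound 2 (beyond the scatter) had tied the read-out to the ring at this chain end, and compound 4 shows that a ring without those two substituents can also give a high read-out when it is joined through oxygen. Nothing measured here on the compounds themselves accounts for this outcome.

With compounds 2, 3 and 4 all within the scatter of one another at a single dose, the compounds shown leave open whether these chain ends differ in potency at lower doses. They also leave open how a cyclohexyl group or a longer chain in place of phenoxy would fare at this position.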